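Aryl urea series: methoxy in place of chloro

The source may hold more compounds than are shown below. What is called first, only, known or untested is meant among the compounds shown, and "the series" means these compounds.

Measured so far:
compound 1, `O=C(Nc1ccccc1Cl)Nc1nn(-c2ccccc2)c(=O)c2ccccc12`: 0%
compound 2, `O=C(Nc1ccc(Cl)cc1)Nc1nn(-c2ccccc2)c(=O)c2ccccc12`: 10%

In an assay on CHO cells for displacement of a labelled ligand from adenosine receptor A1 (Homo sapiens), tested at 10 uM (a lower number here means less inhibition, a higher number more inhibition at the concentration tested (going by the name of the read-out)), compound 1 gives 0% and compound 2 gives 10%. Going by the values given here, the only step measured, a number 10 percentage points higher from compound 1 to compound 2 (within the scatter), moves the chloro from one place on the aryl ring to another and stays within the scatter, so the two numbers cannot be told apart; compound 2 is simply the one with the nearest neighbour compound 1 sitting inside the scatter of it.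

Compound 3, `COc1ccc(NC(=O)Nc2nn(-c3ccccc3)c(=O)c3ccccc23)cc1`, keeps the same core and the 4-substituted aryl urea of compound 2 and differs by methoxy in place of chloro on an aromatic carbon.

Among the compounds with values here, no measured step concerns a methoxy, nor a change of the group itself rather than of its place. Within the data shown here, the one step known, from compound 1 to compound 2, is within the scatter, and both measured numbers sit near the bottom of the read-out. On that basis no step beyond the scatter is expected in this assay: the estimate for compound 3 is 5%, with a range from -10% to 25%, which means an expected step of a number 5 percentage points lower from compound 2 to compound 3 (within the scatter).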

Compound 3, a percentage reported as inhibition, at one concentration (the size of the read-out at that concentration, not a potency): 4%
For compound 3 the middle estimate is 1 percentage points above the measured one; the range from low to high includes it.
By their numbers in this assay, from the lowest: compounds 1, 3 and 2 (each within the scatter of the next).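

In this assay, a change of the group itself on the aryl urea can now be read, not only a change of its place: methoxy in place of chloro on an aromatic carbon, para to a large group, gives a number 6 percentage points lower from compound 2 to compound 3 (within the scatter), so this exchange cannot be told apart from no change at all. With 4-methoxyphenyl in place of 2-chlorophenyl on the amide-type nitrogen, where group and place differ together, the step is a number 4 percentage points higher from compound 1 to compound 3 (within the scatter), so this larger difference also stays inside the scatter. Nothing available explains these numbers.

Open, from the compounds shown here alone, is whether any group on this aryl ring can lift the inhibition clear of the scatter, for instance an amine or a carboxylic acid in place of the methoxy, since chloro and methoxy so far cannot be separated. Also open, going by these compounds, is whether replacing the aryl ring of the urea with a longer alkyl chain, or changing the phenyl on the shared core, would move the number beyond the scatter.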